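A few compounds are considered here, and "the series" means these few. Any claim that something is new, unique, unknown or untested is made for them only; others in the source may bear on it.

Of the compounds shown here, two have been measured in an ADME assay on LLC-MK2 cells (Macaca mulatta) for cytotoxicity, read by spectrophotometry and crystal violet staining, with a stated time of 4 days; a lower number here means that less compound is tolerated, a higher number that more compound is tolerated. Compound 1 `CC(C)n1ncc2c(C(=O)Nc3ccncc3)cc(-c3cccs3)nc21` gives 6300 nM in this assay, the lowest of the two numbers recorded. Compound 2 `CC(C)n1ncc2c(C(=O)Nc3cccnc3)cc(-c3ccsc3)nc21` gives 37000 nM in this assay, a higher number that lies beyond the usual scatter. Compound 2 is not linked to compound 1 by a change at a single site, so the two values are simply compared as they stand.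

Compound 3 `CC(C)n1ncc2c(C(=O)Nc3ccccn3)cc(-c3cccs3)nc21` is the next compound to be tested. It shares every atom with compound 1, joined differently: pyridin-2-yl in place of pyridin-4-yl on an amide-type nitrogen. Only the position of the ring nitrogen moves; nothing is added or removed. Going by the values given here, with no single-site step among the measured compounds to lean on, no direction is favoured, and the step of a 1.1-fold higher number from compound 1 to compound 3 (0.05 log units; within the scatter) is expected to stay within the usual scatter. Compound 3 is therefore expected to give about 7000 nM, with a likely range from 2500 nM to 20000 nM.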

Compound 3, half-maximal cytotoxic concentration: > 200000 nM
Compound 3: a limit, no number (the forecaster's own chance of this, stated with the estimate: 10%); middle value at least 28-fold (1.45 log units) away from the limit.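

Moving only the ring nitrogen, with nothing added or removed, is enough to change the result in this assay: pyridin-2-yl in place of pyridin-4-yl on the amide-type nitrogen gives an at least 31-fold higher number from compound 1 to compound 3 (1.50 log units; beyond the scatter). Compound 1 and compound 2 could not show this, since they differ in more than one place, whereas this single change shows that the outcome in this series can depend on where the nitrogen sits in this ring. For compound 3, the result of > 200000 nM is a limit of the assay and not a number: the limit of > 200000 nM in this assay, at which 1 of the 3 values shown sits.

The true size of this step and the reason for it remain open. So does the result of placing a phenyl ring, which has no ring nitrogen, on the same amide-type nitrogen.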